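Ethyl ester to free acid in a cytotoxicity series

A few compounds are considered here, and "the series" means these few. Any claim that something is new, unique, unknown or untested is made for them only; others in the source may bear on it.

Compound 1 `CCOC(=O)/C=C/c1cc(OC)ccc1OC(=O)c1nc(C)c(C)nc1C` gives 105000 nM in a functional assay on EA.hy 926 cells (Homo sapiens) for cytotoxicity, read by MTT assay, with stated times of 24 h and 12 h; on this read-out higher numbers stand for an effect only at larger amounts of compound and lower numbers for an effect already at smaller amounts.
Compound 2 `CCOC(=O)/C=C/c1cc(Cl)ccc1OC(=O)c1nc(C)c(C)nc1C` gives 36100 nM in this assay.
Compound 3 `CCOC(=O)/C=C/c1cc(OC)c(O)c(OC)c1` gives 67200 nM in this assay.

Among these three numbers compound 2 has the lowest, but the number of compound 3 lies within the usual scatter of it, so the two cannot be told apart. Among the measured compounds shown here, the one single-place step among the measured compounds is a 2.9-fold lower number from compound 1 to compound 2 (0.46 log units; beyond the scatter), chloro in place of methoxy on an aromatic carbon. For the measured compounds named here, compound 3 shares no single-place step with either of the others.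

Compound 4 `Cc1nc(C)c(C(=O)Oc2ccc(Cl)cc2/C=C/C(=O)O)nc1C` differs from compound 2 by hydrogen in place of ethyl on an oxygen next to a carbonyl group. Going by the values given here, no measured step involves this change, and the chloro-for-methoxy step says nothing about an ester becoming an acid. With no evidence either way, a step no larger than the scatter is expected, a 1.4-fold higher number from compound 2 to compound 4 (0.14 log units; within the scatter). Compound 4 is therefore estimated to give 50000 nM in this assay, with a range from 18000 nM to 150000 nM.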

Compound 4, half-maximal effective concentration: 95200 nM
Compound 4: the middle estimate sits 1.9-fold (0.28 log units) below what was measured, within the range that was stated.
By their numbers in this assay, from the lowest: compounds 2, 3, 4 and 1 (each within the scatter of the next, the first and the last beyond it).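

Changing the 2-(ethoxycarbonyl)ethenyl group to 2-carboxyethenyl, with hydrogen in place of ethyl on an oxygen next to a carbonyl group, gives a 2.6-fold higher number from compound 2 to compound 4 (0.42 log units; beyond the scatter) in this assay. A higher number here means that more compound is needed for the same effect, so removing the ethyl moves the result in the direction of a weaker effect. The earlier chloro-for-methoxy step concerned a different place, so only this step shows that the ester end of the molecule also matters in this assay, though the data shown give no explanation for the shift.

On these data alone, whether a methyl ester or a primary amide at this place would fall nearer compound 2 or compound 4 remains open. Also open, as far as these compounds go, is whether the same ethyl-to-hydrogen change on compound 1, which carries methoxy rather than chloro, would give a step of similar size.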